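The source may hold more compounds than are shown below. What is called first, only, known or untested is meant among the compounds shown, and "the series" means these compounds.

The compounds measured in an assay on CHO cells for displacement of a labelled ligand from C-X-C chemokine receptor type 1 (Homo sapiens) (a higher number here means a weaker inhibitor, a lower number a stronger inhibitor), are:

compound 1 `CC[C@@H](Nc1c(Nc2cccc(C(=O)N(C)C)c2O)c(=O)c1=O)c1cc(C)co1`, which gives 9 nM
compound 2 `CCCCc1coc([C@@H](CC)Nc2c(Nc3cccc(C(=O)N(C)C)c3O)c(=O)c2=O)c1`, which gives 34 nM
compound 3 `CCC(CC)c1coc([C@@H](CC)Nc2c(Nc3cccc(C(=O)N(C)C)c3O)c(=O)c2=O)c1`, which gives 30 nM

Compound 1 stands lowest of the three in this assay. Its nearest neighbour is compound 3, reached by a 3.3-fold higher number from compound 1 to compound 3 (0.52 log units; beyond the scatter); the furthest is compound 2, reached by a 3.8-fold higher number from compound 1 to compound 2 (0.58 log units; beyond the scatter). Between the two enlarged compounds the difference, a 1.1-fold lower number from compound 2 to compound 3 (0.05 log units; within the scatter), lies within the scatter, so they cannot be ordered against each other.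

Compound 4 `CC[C@@H](Nc1c(Nc2cccc(C(=O)N(C)C)c2O)c(=O)c1=O)c1cc(C2CCCC2)co1` has not been measured. Relative to compound 1 the change is cyclopentyl in place of methyl on an aromatic carbon. For the measured compounds named here, the step that bears on it most directly is the one from compound 1 to compound 3, since it changes the same aromatic carbon from methyl to a larger alkyl group and is modest but beyond the scatter. The step from compound 1 to compound 2 enlarges an alkyl group at a different place and is of similar size. Both point the same way, so a modest rise in the number is expected, not a large one.

Compound 4 is therefore expected to give 25 nM in this assay, in the range 10 nM to 60 nM, meaning the step of a 2.8-fold higher number from compound 1 to compound 4 (0.44 log units; beyond the scatter) is estimated.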

Compound 4, inhibition constant: 53 nM
The estimate for compound 4 lay 2.1-fold (0.33 log units) below the measured number; low and high end bracket the measured number.
By their numbers in this assay, from the lowest: compound 1; then compounds 3, 2 and 4 (each within the scatter of the next).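

In this assay, for the compounds shown here, replacing 4-methylfuran-2-yl with 4-cyclopentylfuran-2-yl gives a 5.9-fold higher number from compound 1 to compound 4 (0.77 log units; beyond the scatter) and leaves compound 1 the strongest inhibitor of the four, with methyl the only group on this aromatic carbon that stands apart from the others. Closing the larger group into a ring of carbon only brings no readable difference from the open chains, as a 1.8-fold higher number from compound 3 to compound 4 (0.25 log units; within the scatter) and a 1.6-fold higher number from compound 2 to compound 4 (0.19 log units; within the scatter) both leave the pairs unordered, so cyclopentyl, pentan-3-yl and butyl cannot be ranked at this position. Nothing given here explains why these three larger groups sit together or why methyl differs from them.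

The compounds shown leave open how the number behaves for groups smaller than these three, such as hydrogen, ethyl or cyclopropyl, and so where between methyl and the larger groups the step arises. They also leave open whether a ring holding oxygen, such as tetrahydropyran-4-yl, or an amine such as dimethylamino would fall with the larger alkyl groups on this carbon or stay closer to compound 1.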